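A few compounds are considered here, and "the series" means these few. Any claim that something is new, unique, unknown or untested is made for them only; others in the source may bear on it.

Compound 2 `O=C(CCCCC1CCSS1)NCc1cn(CCCOc2ccc3cc(C(=O)O)c(=O)oc3c2)nn1` gives 73.5% in a functional assay on PC-12 cells (Rattus norvegicus) for cytotoxicity, read by MTT assay, with stated times of 3 h and 2 h, tested at 50 uM (a lower number here means a weaker effect, a higher number a stronger effect of the compound at the concentration tested), the highest of the three numbers measured, with compound 1 `CCOC(=O)c1cc2ccc(OCCCn3cc(CNC(=O)CCCCC4CCSS4)nn3)cc2oc1=O` at 49.2% and compound 3 `O=C(CCCCC1CCSS1)NCc1cn(CCCOc2ccc3cc(-c4ccccc4)c(=O)oc3c2)nn1` at 23.1%. Compound 4 `O=C(CCCCC1CCSS1)NCc1cn(CCCOc2ccc3cc(-c4ccc(Cl)c(Cl)c4)c(=O)oc3c2)nn1` has not yet been measured; it differs from compound 2 in one place: 3,4-dichlorophenyl in place of carboxy on an aromatic carbon. The step that bears most directly on this change is a number 50.4 percentage points lower from compound 2 to compound 3 (beyond the scatter), a large drop when an aromatic ring replaced the carboxy group at the same position. The step of a number 26.1 percentage points lower from compound 1 to compound 3 (beyond the scatter) points the same way. The change to compound 4 again places an aromatic ring there, so a large fall is expected, roughly a number 48.5 percentage points lower from compound 2 to compound 4 (beyond the scatter). Compound 4 is therefore estimated at 25%, between 8% and 42%.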

Compound 4, a percentage reported as activity, at one concentration (the size of the read-out at that concentration, not a potency): 54.8%
Compound 4: the middle estimate sits 29.8 percentage points below what was measured; measured number outside the range, above it.
By their numbers in this assay, from the lowest: compound 3; then compounds 1 and 4 (each within the scatter of the next); then compound 2.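

In this assay an aromatic ring at this position does not settle the read-out: 3,4-dichlorophenyl in place of phenyl gives a number 31.7 percentage points higher from compound 3 to compound 4 (beyond the scatter), so the large fall seen earlier does not hold for every aromatic ring here. Carboxy to 3,4-dichlorophenyl still gives a number 18.7 percentage points lower from compound 2 to compound 4 (beyond the scatter), while ethoxycarbonyl to 3,4-dichlorophenyl gives a number 5.6 percentage points higher from compound 1 to compound 4 (within the scatter). Nothing measured here explains what the two chlorines do. From the compounds shown here alone, whether a single chlorine, a methoxy group or an amine on the phenyl ring would give a number nearer that of compound 3 or compound 4 remains open.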